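Swapping 3-chlorophenyl for benzyl: what to expect

A few compounds are considered here, and "the series" means these few. Any claim that something is new, unique, unknown or untested is made for them only; others in the source may bear on it.

Compound 1 `CC1(C)CC(NC(=O)Nc2cccc(Cl)c2)c2cc(Br)ccc2O1` gives 67000 nM
Compound 2 `CC1(C)CC(NC(=S)Nc2cccc(C#N)c2)c2cc(Br)ccc2O1` gives 9000 nM

These two numbers come from a functional assay on T98G cells (Homo sapiens) for inhibition, read by MTT assay, with a stated time of 72 h (a lower number here means a stronger inhibitor, a higher number a weaker inhibitor), and they allow one direct comparison. Compound 1 has the higher number of the pair, which makes it the weaker inhibitor. The number for compound 2 (9000 nM) is lower by more than the usual scatter of repeated measurements.

The next compound, compound 3 `CC1(C)CC(NC(=O)NCc2ccccc2)c2cc(Br)ccc2O1`, keeps the core of compound 1 and changes one place: benzyl in place of 3-chlorophenyl on an amide-type nitrogen. The group that enters, like the one that leaves, holds one six-membered aromatic ring of carbon only.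

Going by the values given here, the two measured compounds differ in more than one place, so this swap has no measured precedent. The expectation therefore starts from compound 1 (67000 nM) and stays close to it. The expected change (a 1.2-fold higher number from compound 1 to compound 3 (0.08 log units; within the scatter)) is a slightly higher number, but not one beyond the scatter. For compound 3 the estimated value is 80000 nM (expected range 25000 nM to 200000 nM).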

Compound 3, half-maximal inhibitory concentration: 38000 nM
For compound 3 the middle estimate is 2.1-fold (0.32 log units) above the measured one; measured number inside the range.
By their numbers in this assay, from the lowest: compound 2; then compounds 3 and 1 (each within the scatter of the next).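

In this assay, going by these compounds alone, this is the first step that can be read at this position, the amide-type nitrogen of the shared core: a 1.8-fold lower number from compound 1 to compound 3 (0.25 log units; within the scatter). Replacing 3-chlorophenyl with benzyl keeps the count of heavy atoms and the single six-membered aromatic ring of carbon only, but exchanges the chlorine for a carbon, and this whole exchange leaves the two compounds indistinguishable in this read-out, so neither can be called the stronger inhibitor. No outside measurement bears on this result, so the data offer no explanation for it.

The swap changes two things at once, removing the chlorine and turning a phenyl group into a benzyl group, and this single step cannot show what each change would do alone, so a plain phenyl or a 3-chlorobenzyl group on this nitrogen would be needed to separate them. On these data alone, it also remains open whether a longer chain such as 2-phenylethyl, or a group without an aromatic ring such as cyclohexyl, would move the number beyond the usual scatter of repeated measurements.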